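Methyl in place of thiophen-2-yl on the shared core

A few compounds are considered here, and "the series" means these few. Any claim that something is new, unique, unknown or untested is made for them only; others in the source may bear on it.

Of the compounds shown here, three sharing one core have been tested in a functional assay on HeLa S3 cells (Homo sapiens) for cytotoxicity, read by XTT assay, with a stated time of 6 days; a lower number here means a stronger inhibitor, a higher number a weaker inhibitor. Compound 1 `CN(C)c1ncnc2[nH]cc(Sc3cccs3)c12` gives > 25000 nM, which is a limit of the assay. Compound 2 `Nc1ncnc2[nH]cc(Sc3cccs3)c12` gives a true number, 17900 nM. Compound 3 `c1csc(Sc2c[nH]c3ncnc(-c4cccs4)c23)c1` gives > 25000 nM, again a limit, so it has no exact place on the scale. The data are thus dominated by the limit of > 25000 nM in this assay, at which 2 of the 3 values shown sit.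

Compound 4 `Cc1ncnc2[nH]cc(Sc3cccs3)c12` carries methyl in place of thiophen-2-yl on an aromatic carbon, a change counted as methyl in place of thiophen-2-yl on an aromatic carbon. The measured steps all swap the group on that same carbon: an at least 1.3-fold lower number from compound 1 to compound 2 (0.14 log units; that floor lies within the scatter), an at least 1.3-fold higher number from compound 2 to compound 3 (0.14 log units; that floor lies within the scatter) and a step that the two limits leave unreadable from compound 1 to compound 3. None of them is shown to exceed the scatter, so no step beyond the scatter is expected in this assay. The expected step is an at least 1.2-fold lower number from compound 3 to compound 4 (0.09 log units; that floor lies within the scatter). A reading that is again only a limit is quite possible. The estimate for compound 4 is 20000 nM, with an expected range from 9000 nM to 40000 nM.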

Compound 4, half-maximal inhibitory concentration: > 25000 nM
Compound 4: a limit, no number (the forecaster's own chance of this, stated with the estimate: 55%); at least 1.2-fold (0.09 log units) between middle value and limit.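

In this assay compound 4 gives > 25000 nM, which is a limit of the assay and not a number. With the ring of thiophen-2-yl replaced by methyl, which has no ring, the one readable step is an at least 1.3-fold higher number from compound 2 to compound 4 (0.14 log units; that floor lies within the scatter), so the amino group of compound 2 is not shown to differ from methyl beyond the scatter. The steps to compound 4 from compound 1 and from compound 3 cannot be read, because the values at both ends are limits: the limit of > 25000 nM in this assay, at which 3 of the 4 values shown sit.

The compounds shown leave open whether any group on this aromatic carbon, such as a hydroxyl, a methylamino group or a chlorine, gives a clearly lower number than the amino group does. On these data alone, the sulfur-linked thiophene stays the same in all four compounds, so its part in these values remains unknown.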